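Acyl chain lengthening on an anilide sulfonate series

The source may hold more compounds than are shown below. What is called first, only, known or untested is meant among the compounds shown, and "the series" means these compounds.

Measured so far:
compound 1 `CC(=O)Nc1cccc(S(=O)(=O)Oc2ccccc2C(C)C)c1`, which in a functional assay on MCF7 cells (Homo sapiens) for antiproliferative activity, read by sulforhodamine B assay, with a stated time of 48 h (on this read-out higher numbers stand for weaker inhibition and lower numbers for stronger inhibition), gives 21000 nM
compound 2 `CCC(=O)Nc1cccc(S(=O)(=O)Oc2ccccc2C(C)C)c1`, which in this assay gives 14000 nM

Going by the values given here, compound 2 holds the lower of the two numbers in this assay, but its only neighbour is compound 1 and the step of a 1.5-fold lower number from compound 1 to compound 2 (0.18 log units; within the scatter) lies within the scatter, so no order between the two can be read from these values.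

Compound 3 `CCCC(=O)Nc1cccc(S(=O)(=O)Oc2ccccc2C(C)C)c1` continues the same line: relative to compound 2 the change is methyl in place of hydrogen on a saturated chain carbon, two bonds along the chain from a carbonyl carbon. Among the compounds with values here, the one measured step that bears on it is the step from compound 1 to compound 2, where a methyl was added one bond closer to the carbonyl; that step, a 1.5-fold lower number from compound 1 to compound 2 (0.18 log units; within the scatter), did not rise above the scatter. Nothing here supports a larger movement for the next addition along the chain, and the direction, if any, is the same slight lowering.

Compound 3 is therefore expected to give about 10000 nM in this assay, with a range of 4000 nM to 25000 nM. The expected step of a 1.4-fold lower number from compound 2 to compound 3 (0.15 log units; within the scatter) should stay within the scatter.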

Compound 3, half-maximal inhibitory concentration: 9400 nM
For compound 3 the middle estimate is 1.1-fold (0.03 log units) above the measured one; the range from low to high includes it.
By their numbers in this assay, from the lowest: compounds 3, 2 and 1 (each within the scatter of the next, the first and the last beyond it).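

In this assay the added methyl, two bonds along the chain from a carbonyl carbon, gives a 1.5-fold lower number from compound 2 to compound 3 (0.17 log units; within the scatter) and so, taken alone, establishes no order between these two compounds, just as the earlier methyl addition gave none. Going by these compounds alone, the new information comes from reading the two additions together: the single change that spans both gives a 2.2-fold lower number from compound 1 to compound 3 (0.35 log units; beyond the scatter) and is the first step in this short series to clear the scatter, though only modestly, so a real difference at this position appears only across the full change and not at either single addition. No supporting measurement is available to explain this difference.

Whether a longer chain such as pentanoyl or hexanoyl would extend the same direction or level off remains open, and three compounds cannot define a trend beyond the propanoyl-to-butanoyl range shown here. Also open, on these data alone, is how this position responds to something other than an unbranched chain, such as a branched isopropyl end, a cyclopropyl ring, or an amine or carboxylic acid at the chain end.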